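The source may hold more compounds than are shown below. What is called first, only, known or untested is meant among the compounds shown, and "the series" means these compounds.

Measured compounds:
compound 1, `Cc1ccc(NC2=CC(=O)c3c(nc4n3[C@H]3OC[C@@H](O)[C@H]3OC4)C2=O)cc1C` — 4090 nM
compound 2, `O=C1C=C(Nc2ccc(C(F)(F)F)cc2)C(=O)c2c1nc1n2[C@H]2OC[C@@H](O)[C@H]2OC1` — 5500 nM
compound 3, `CCOc1ccccc1NC1=CC(=O)c2c(nc3n2[C@H]2OC[C@@H](O)[C@H]2OC3)C1=O` — 4320 nM

Among the three measured compounds, compound 2 shows the highest number in a functional assay on ECa-109 cells for inhibition, with ECa-109 cell line (Homo sapiens) as the target, read by sulforhodamine B assay (a higher number here means a weaker inhibitor, a lower number a stronger inhibitor), but its gap to compound 3 and its gap to compound 1 are both within the scatter, so the three stand together rather than in any order. Going by the values given here, the only measured step between compounds differing in one place is a 1.1-fold higher number from compound 1 to compound 3 (0.02 log units; within the scatter), which exchanges one aryl substituent pattern for another on the amine nitrogen and leaves this assay unchanged within the scatter.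

Compound 4 is `CCOc1ccc(NC2=CC(=O)c3nc4n(c3C2=O)[C@H]2OC[C@@H](O)[C@H]2OC4)cc1`. It arises from compound 2 by ethoxy in place of trifluoromethyl on an aromatic carbon. Among the compounds with values here, no measured step exchanges trifluoromethyl for ethoxy, and no measured step alters a group at this place, so the only guidance is indirect: a change of the aryl substituents, as in the step from compound 1 to compound 3, did not move this assay beyond the scatter. On that basis the step of a 1.2-fold lower number from compound 2 to compound 4 (0.09 log units; within the scatter) is expected to stay within the scatter, with no particular direction. For compound 4 the estimated value in this assay is 4500 nM, with an expected range from 2200 nM to 9000 nM.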

Compound 4, half-maximal inhibitory concentration: 3210 nM
For compound 4 the middle estimate is 1.4-fold (0.15 log units) above the measured one; the measured number falls inside the stated range.
By their numbers in this assay, from the lowest: compounds 4, 1, 3 and 2 (each within the scatter of the next).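

In this assay, going by these compounds alone, the exchange of 4-(trifluoromethyl)phenyl for 4-ethoxyphenyl gives a 1.7-fold lower number from compound 2 to compound 4 (0.23 log units; within the scatter), which is the first reading of a single exchange at this place, on an aromatic carbon para to a large group. The two groups differ in their atoms and in their count under hydrogen-bond acceptors, with 0 for trifluoromethyl and 1 for ethoxy, yet the step does not leave the scatter, so this one exchange at this place gives no separation in this read-out. The earlier step concerned a different exchange of aryl substituents, so this result extends the flat picture to a new pair of groups, though only for this pair and this cell line. No measurement at hand bears on why the number holds across this exchange.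

The compounds shown leave open whether a carboxylic acid, an amine or a longer alkoxy chain on the same aromatic carbon would move the number beyond the scatter. They also leave open whether any change on the shared core, rather than on the aryl group, would separate these compounds in this assay.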